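Shortening the Hydroxamate Chain on the Benzoxazole Series

The source may hold more compounds than are shown below. What is called first, only, known or untested is meant among the compounds shown, and "the series" means these compounds.

Compounds measured so far:
compound 1, `CNC(=O)CCCCCCCn1nc(-c2ccc3oc(N)nc3c2)c2c(N)ncnc21`: 3150 nM
compound 2, `Nc1ncnc2c1c(-c1cnc3[nH]ccc3c1)nn2CCCC(=O)NO`: > 150000 nM (a limit)
compound 3, `Nc1ncnc2c1c(-c1cnc3[nH]ccc3c1)nn2CCCCCCCCC(=O)NO`: 5460 nM

In a functional assay on HCT-116 cells (Homo sapiens) for inhibition, read by MTT assay, with a stated time of 72 h (on this read-out higher numbers stand for weaker inhibition and lower numbers for stronger inhibition), compound 1 gives 3150 nM, the lowest of the two numbers recorded. Compound 3 gives 5460 nM in this assay, and the gap to compound 1 lies within the scatter, so the two cannot be ordered. For compound 2 this assay reports only a limit, (the limit of > 150000 nM in this assay, at which 1 of the 3 values shown sits). For the measured compounds named here, the one step measured between two compounds is an at least 27-fold lower number from compound 2 to compound 3 (1.43 log units; beyond the scatter), so a longer hydroxamate chain went with a far lower number.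

Compound 4, `Nc1nc2cc(-c3nn(CCC(=O)NO)c4ncnc(N)c34)ccc2o1`, is not yet measured. It differs from compound 1 by hydroxycarbamoyl in place of 5-(methylcarbamoyl)pentyl on a saturated chain carbon, two bonds along the chain from an aromatic nitrogen. Compound 4 thus carries a hydroxycarbamoyl group on a very short chain, as compound 2 does on its core, while compound 3 and compound 1 carry their terminal amide groups at the end of long chains. Going by the values given here, the step of an at least 27-fold lower number from compound 2 to compound 3 (1.43 log units; beyond the scatter) is the only guide, and it points to a large rise in the number when the chain is cut short.

The number for compound 4 is therefore expected to rise sharply, a 38-fold higher number from compound 1 to compound 4 (1.58 log units; beyond the scatter), and may well sit at the limit of this assay. The estimate for compound 4 is 120000 nM, expected to fall between 20000 nM and 400000 nM.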

Compound 4, half-maximal inhibitory concentration: > 100000 nM
Compound 4: a limit, no number (the forecaster's own chance of this, stated with the estimate: 55%); the middle value is on the limit's open side.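

In this assay, hydroxycarbamoyl in place of 5-(methylcarbamoyl)pentyl on a saturated chain carbon, two bonds along the chain from an aromatic nitrogen, gives an at least 31-fold higher number from compound 1 to compound 4 (1.50 log units; beyond the scatter). The earlier large step belonged to the core of compound 2 and compound 3, so this result shows that a large change also goes with a short chain on the core of compound 1, even with a hydroxycarbamoyl end group in place. Compound 4 gives no number here, only a limit: the limit of > 100000 nM in this assay, at which 1 of the 4 values shown sits.

This one step changes the length of the chain and its end group together, and the compounds shown cannot tell how much of it belongs to each change. Also open, as far as these compounds go, is how a short chain ending in methylcarbamoyl, a long chain ending in hydroxycarbamoyl or a chain ending in a carboxylic acid would read on the core of compound 1.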